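The source may report more compounds than this note shows. Statements on the series, on what has been measured and on what is new or still open speak of the compounds shown alone.

In a functional assay on the whole organism for agonist activity, with Mus musculus as the target (a lower number here means that less compound is needed, a higher number that more compound is needed for the effect), compound 1 (`COC(=O)N(C)CC#CCn1cncc1C`) gives 4.5 mg/kg and compound 2 (`Cn1ccn(CC#CCN2CCCC2)c1=O`) gives 3.7 mg/kg as its value, and these two lie within the scatter of each other. Compound 3 (`Cn1ccn(CC#CCn2ccnc2)c1=O`) has not yet been measured. It carries 1H-imidazol-1-yl in place of the pyrrolidin-1-yl of compound 2 on a saturated chain carbon bound to a triple-bonded carbon (1H-imidazol-1-yl in place of pyrrolidin-1-yl on a saturated chain carbon bound to a triple-bonded carbon). Within the data shown here, no measured step shows the size of such a change. The expected change is a 4.1-fold higher number from compound 2 to compound 3 (0.61 log units; beyond the scatter) toward a higher number and beyond the scatter. For compound 3 the estimated value is 15 mg/kg with an expected range from 4 mg/kg to 60 mg/kg in this read-out.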

Compound 3, dose for half-maximal effect: 4.5 mg/kg
For compound 3 the middle estimate is 3.3-fold (0.52 log units) above the measured one; low and high end bracket the measured number.
By their numbers in this assay, from the lowest: compounds 2, 1 and 3 (each within the scatter of the next).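

On the saturated chain carbon bound to a triple-bonded carbon, 1H-imidazol-1-yl in place of pyrrolidin-1-yl gives a 1.2-fold higher number from compound 2 to compound 3 (0.09 log units; within the scatter) in this assay. In this read-out, the place therefore takes a five-membered aromatic ring as well as a five-membered non-aromatic ring, with no step beyond the scatter. Nothing measured on these compounds accounts for this result.

Open, as far as these compounds go, is whether an open-chain dimethylamino group or a carboxylic acid at this place stays within the scatter of compound 2. Also open, from the compounds shown here alone, is whether a longer chain in place of the chain carrying these rings leaves the read-out unchanged.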